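Acetamido in place of bromo in a cytotoxic series

The compounds below may be only part of what the source reports. "The series", "measured", "known", "first", "only" and "open" are said of these compounds alone.

In a functional assay on HepG2 cells (Homo sapiens) for cytotoxicity, read by MTT assay, with a stated time of 24 h (on this read-out lower numbers stand for stronger inhibition and higher numbers for weaker inhibition), compound 1 (`Cc1ccc(S(=O)(=O)N2C/C(=C\c3ccncc3)C(=O)/C(=C/c3ccccc3C(F)(F)F)C2)cc1`) gives 4640 nM and compound 2 (`O=C1/C(=C/c2ccncc2)CN(S(=O)(=O)c2ccc(Br)cc2)C/C1=C\c1ccccc1C(F)(F)F`) gives 14500 nM as the higher of the two numbers. Compound 3 (`CC(=O)Nc1ccc(S(=O)(=O)N2C/C(=C\c3ccncc3)C(=O)/C(=C/c3ccccc3C(F)(F)F)C2)cc1`) differs from compound 2 by acetamido in place of bromo on an aromatic carbon. Within the data shown here, the only measured step at this place is modest but beyond the scatter (a 3.1-fold higher number from compound 1 to compound 2 (0.49 log units; beyond the scatter)), and it does not involve acetamido. A step of similar size toward a lower number is therefore expected (a 2.4-fold lower number from compound 2 to compound 3 (0.38 log units; beyond the scatter)), with little certainty. Compound 3 is expected at 6000 nM (2000 nM to 18000 nM).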

Compound 3, half-maximal inhibitory concentration: 4840 nM
Compound 3: middle estimate off by 1.2-fold (0.09 log units), on the high side; the measured number falls inside the stated range.
By their numbers in this assay, from the lowest: compounds 1 and 3 (each within the scatter of the next); then compound 2.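

In this assay, the change from bromo to acetamido on this aromatic carbon is a step of its own (a 3.0-fold lower number from compound 2 to compound 3 (0.48 log units; beyond the scatter)), so the number at this position does not simply rise with the size of the group. Acetamido and methyl cannot be told apart here (a 1.0-fold higher number from compound 1 to compound 3 (0.02 log units; within the scatter)), which leaves bromo alone of the three with the higher number. Nothing available explains this difference.

On these data alone, whether an amine or a carboxylic acid at this position would stay level with methyl and acetamido or move toward bromo remains open. So does whether chloro would behave like bromo.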